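Bromo to chloro on the aryl piperidine amide

The source may hold more compounds than are shown below. What is called first, only, known or untested is meant among the compounds shown, and "the series" means these compounds.

Of the compounds shown here, three built around a shared core have been tested in a functional assay for antagonist activity at transient receptor potential cation channel subfamily V member 1 (Homo sapiens), read by FLIPR and calcium flux; a lower number here means a stronger inhibitor, a higher number a weaker inhibitor. Compound 1 `O=C1CSc2ccc(NC(=O)C3CCN(c4cc(F)c(F)c(F)c4)CC3)cc2N1` gives 1960 nM in this assay. Compound 2 `CCOC(=O)C1(C)Oc2ccc(NC(=O)C3CCN(c4cc(F)c(F)c(F)c4)CC3)cc2NC1=O` gives 870 nM in this assay. Compound 3 `O=C1COc2ccc(NC(=O)C3CCN(c4ccccc4Br)CC3)cc2N1` gives 160 nM in this assay, the lowest of the three numbers; the gap to compound 2 and the larger gap to compound 1 both lie beyond the usual scatter, so compound 3 stands as the strongest inhibitor of the set on these numbers.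

Compound 4 `O=C1COc2ccc(NC(=O)C3CCN(c4ccccc4Cl)CC3)cc2N1` has not yet been measured. It differs from compound 3 in a single place: chloro in place of bromo on an aromatic carbon. Within the data shown here, no pair of measured compounds shows this kind of exchange, so there is no measured step to lean on. Exchanging one halogen for another of similar kind at the same aromatic carbon generally moves the number only a little. The step from compound 3 to compound 4 is therefore expected to be small, most likely toward a slightly higher number, but possibly none beyond the scatter, as a 1.6-fold higher number from compound 3 to compound 4 (0.19 log units; within the scatter) expresses. On that basis compound 4 is estimated to give 250 nM in this assay, with a range from 100 nM to 650 nM.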

Compound 4, half-maximal inhibitory concentration: 220 nM
The estimate for compound 4 lay 1.1-fold (0.06 log units) above the measured number; measured number inside the range.
By their numbers in this assay, from the lowest: compounds 3 and 4 (each within the scatter of the next); then compound 2; then compound 1.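

Across the exchange of bromo for chloro on this aromatic carbon, ortho to a large group, the record reads a 1.4-fold higher number from compound 3 to compound 4 (0.14 log units; within the scatter) in this assay and so the 2-bromophenyl and 2-chlorophenyl compounds cannot be told apart on these numbers. Among these compounds, this is the first step that can be read at a single place, since compounds 1, 2 and 3 differ from one another in more than one place and could say nothing on their own about this position, whereas the pair shows that here one of these halogens can stand in for the other without a change beyond the scatter. Nothing in the available data gives a reason for this outcome.

From the compounds shown here alone, the pair speaks only for these two halogens, so it remains open how the number would respond to a different group on the same carbon, such as a methyl, a methoxy, an amine or a carboxylic acid, or to a hydrogen there. Among the compounds shown here, also open is how much of the gaps to compound 1 and compound 2 belongs to the fluoro-substituted aryl group and how much to the other parts of those molecules, as no single-place step connects them to compound 3 or compound 4.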